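The compounds below may be only part of what the source reports. "The series", "measured", "known", "first", "only" and "open" are said of these compounds alone.

Compound 1 `O=C(CO[N+](=O)[O-])Nc1ccc(C(=O)/C=C/c2ccc(Cl)cc2)cc1`: 69%
Compound 2 `CC(=O)c1ccc(OCC(=O)Nc2ccc(C(=O)/C=C/c3ccc(Cl)cc3)cc2)cc1`: 61%

In a functional assay on the whole organism (strain albino) for inhibition, with Rattus norvegicus as the target, read by paw edema, with stated times of 30 min and 3 h, at a dose of 100 mg/kg by the oral route (a higher number here means more inhibition at the dose given (going by the name of the read-out), a lower number less inhibition), compound 1 gives 69% and compound 2 gives 61%. Compound 2 stands level with compound 1 on these numbers, since the step of a number 8 percentage points lower from compound 1 to compound 2 (within the scatter) lies within the scatter, so the two cannot be told apart. Compound 3 `C/C(=N/O)c1ccc(OCC(=O)Nc2ccc(C(=O)/C=C/c3ccc(Cl)cc3)cc2)cc1` differs from compound 2 by a group of 4 heavy atoms (2 carbon, 1 nitrogen, 1 oxygen; no ring) in place of a group of 3 heavy atoms (2 carbon, 1 oxygen; no ring), on an aromatic carbon. Within the data shown here, no measured step touches the acetyl; the only step on record, a number 8 percentage points lower from compound 1 to compound 2 (within the scatter), changed a different part and stayed within the scatter. No step beyond the scatter is therefore expected in this assay. Compound 3 is expected to give about 62%, in the range 50% to 74%. This means an expected step of a number 1 percentage points higher from compound 2 to compound 3 (within the scatter).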

Compound 3, a percentage reported as inhibition, in the whole organism at one dose (the size of the read-out at that dose, not a potency): 66%
Compound 3: middle estimate off by 4 percentage points, on the low side; measured number inside the range.
By their numbers in this assay, from the lowest: compounds 2, 3 and 1 (each within the scatter of the next).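

In this assay, the acetyl on the aromatic carbon, para to a large group, gives way to a group that brings a nitrogen and a hydrogen-bond donor, yet the number does not move beyond the scatter (a number 5 percentage points higher from compound 2 to compound 3 (within the scatter)). This new group, carried on the larger aromatic substituent, also stays level with the nitro on the oxygen (a number 3 percentage points lower from compound 1 to compound 3 (within the scatter)). Nothing measured here gives a cause for these numbers. From the compounds shown here alone, whether an amine or a carboxylic acid at this aromatic carbon would hold the number stays open.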